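A methoxy added to a weakly cytotoxic amidine

The compounds below may be only part of what the source reports. "The series", "measured", "known", "first", "only" and "open" are said of these compounds alone.

Three compounds share one core. Compound 1 `COc1ccc(CNC(=N)[C@@H]2CCC(=O)N2Cc2ccccc2)cc1` gives 19.5% in a functional assay on SH-SY5Y cells (Homo sapiens) for cytotoxicity, read by MTT assay, with stated times of 8 h, 30 min and 12 h, tested at 5 uM (a lower number here means a weaker effect, a higher number a stronger effect of the compound at the concentration tested), compound 2 `COc1ccc(CNC(=N)[C@@H]2CCC(=O)N2Cc2ccccc2[N+](=O)[O-])cc1` gives 25.4%, and compound 3 `Cc1ccc(CN2C(=O)CC[C@H]2C(=N)NCc2ccccc2)cc1` gives 24.8%, the second highest of the three numbers, though its gaps to both others lie within the scatter. The unmeasured compound 4 `COc1ccc(CNC(=N)[C@@H]2CCC(=O)N2Cc2ccc(C)cc2)cc1` differs from compound 3 by one change: methoxy in place of hydrogen on an aromatic carbon. Within the data shown here, the only measured single step, a number 5.9 percentage points higher from compound 1 to compound 2 (within the scatter), concerns a different ring and a different group, so no step directly tests a methoxy. Compound 1 and compound 3 differ in two places, and their values show no gap beyond the scatter. The expected step of a number 0.8 percentage points lower from compound 3 to compound 4 (within the scatter) is therefore none beyond the scatter, and compound 4 is estimated at 24%, between 14% and 34%.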

Compound 4, a percentage reported as activity, at one concentration (the size of the read-out at that concentration, not a potency): 29.5%
Compound 4: the middle estimate sits 5.5 percentage points below what was measured; the measured number falls inside the stated range.
By their numbers in this assay, from the lowest: compounds 1, 3, 2 and 4 (each within the scatter of the next).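

In this assay, among these compounds, phenyl to 4-methoxyphenyl, a change no earlier pair tested directly, gives a number 4.7 percentage points higher from compound 3 to compound 4 (within the scatter), so methoxy at this place shows no effect beyond the scatter. Methyl in place of hydrogen on the other aromatic ring gives a number 10 percentage points higher from compound 1 to compound 4 (within the scatter), and 4-methylphenyl in place of 2-nitrophenyl gives a number 4.1 percentage points higher from compound 2 to compound 4 (within the scatter), so neither change stands out either. No evidence here points to a cause. On these data alone, whether an amine or a carboxylic acid at this same place would step beyond the scatter stays open, as does a longer chain such as ethoxy.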